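The source may report more compounds than this note shows. Statements on the series, on what has been measured and on what is new or still open speak of the compounds shown alone.

Three analogues built on one shared core have been measured in a functional assay on HepG2 cells (Homo sapiens) for antiproliferative activity, read by MTT assay, with a stated time of 48 h; a higher number here means a weaker inhibitor, a lower number a stronger inhibitor. Compound 1 `CCOc1ccc(C(=O)/C=C/c2c(/C=C/c3ccc(OC)cc3)cc(OC)cc2OC)cc1` gives 8 ug/mL, compound 2 `COc1ccc(/C=C/c2cc(OC)cc(OC)c2/C=C/C(=O)c2ccc(C(F)(F)F)cc2)cc1` gives 18.7 ug/mL, and compound 3 `COc1ccc(/C=C/c2cc(OC)cc(OC)c2/C=C/C(=O)c2cccc(Cl)c2)cc1` gives 9.5 ug/mL. Compound 3 thus stands second highest of the three numbers: its nearest neighbour is compound 1, with a 1.2-fold higher number from compound 1 to compound 3 (0.07 log units; within the scatter) inside the scatter, and its furthest is compound 2, with a 2.0-fold lower number from compound 2 to compound 3 (0.29 log units; within the scatter) also inside the scatter. For the measured compounds named here, the only step beyond the scatter is a 2.3-fold higher number from compound 1 to compound 2 (0.37 log units; beyond the scatter).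

Compound 4 `COc1ccc(/C=C/c2cc(OC)cc(OC)c2/C=C/C(=O)c2ccc(C)c(C)c2)cc1` differs from compound 3 in a single place: 3,4-dimethylphenyl in place of 3-chlorophenyl on a carbonyl carbon. Going by the values given here, the steps that bear on this change are the two earlier swaps of the aryl group on the carbonyl carbon, a 1.2-fold higher number from compound 1 to compound 3 (0.07 log units; within the scatter) and a 2.0-fold lower number from compound 2 to compound 3 (0.29 log units; within the scatter), both of which stayed within the scatter. Compound 4 is therefore expected to show no step beyond the scatter, no change at the digits printed from compound 3 to compound 4 (within the scatter). The estimate for compound 4 in this assay is 9.5 ug/mL, with a range from 5 ug/mL to 19 ug/mL.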

Compound 4, half-maximal inhibitory concentration: 0.2 ug/mL
Compound 4: the middle estimate sits 48-fold (1.68 log units) above what was measured, outside the stated range (below it).
By their numbers in this assay, from the lowest: compound 4; then compounds 1, 3 and 2 (each within the scatter of the next, the first and the last beyond it).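

Swaps of the aryl group on the carbonyl carbon had so far moved the number modestly at most, yet in this assay the 3,4-dimethylphenyl group in place of 3-chlorophenyl produces a large step (a 48-fold lower number from compound 3 to compound 4 (1.68 log units; beyond the scatter)), so this position can carry a far greater change than the earlier compounds showed. The step is just as large against the other two aryl groups (a 94-fold lower number from compound 2 to compound 4 (1.97 log units; beyond the scatter)) and (a 40-fold lower number from compound 1 to compound 4 (1.60 log units; beyond the scatter)), which makes compound 4 the strongest inhibitor of the four. No measurement is at hand that explains why this particular group gives so large a step.

The compounds shown leave open whether both methyl groups are needed or whether one alone would give a step of this size. They also leave open how an amine or a carboxylic acid on this same aryl ring would read.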